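A few compounds are considered here, and "the series" means these few. Any claim that something is new, unique, unknown or untested is made for them only; others in the source may bear on it.

For the measured compounds named here, compound 1, `CC(C)(C)c1ccc(C(=O)N2CCC3(CC2)C(=O)N(CC(=O)NCN)CN3c2ccccc2)cc1`, is the weakest binder among the three compounds measured so far: in an assay on HEK293 cells for displacement of a labelled ligand from NPC1-like intracellular cholesterol transporter 1 (Homo sapiens) (a higher number here means a weaker inhibitor, a lower number a stronger inhibitor), compound 1 gives 26500 nM, the highest of the three numbers. Compound 2, `O=C(CN1CN(c2ccccc2)C2(CCN(C(=O)c3ccc(C4CCCCC4)cc3)CC2)C1=O)NCCCCO`, gives 10300 nM, and compound 3, `COC(=O)CCNC(=O)CN1CN(c2ccccc2)C2(CCN(C(=O)c3ccc(C4CCCCC4)cc3)CC2)C1=O`, gives 12900 nM. Going by the values given here, both carry a different group on the benzamide than compound 1, so no single-point step links compound 1 to either of them; their values simply sit lower. Among the compounds with values here, the one step that is single-point, a 1.3-fold higher number from compound 2 to compound 3 (0.10 log units; within the scatter), alters the tail of the chain beyond the amide-type nitrogen and changes nothing beyond the scatter.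

The unmeasured compound 4, `CC(C)(C)c1ccc(C(=O)N2CCC3(CC2)C(=O)N(CC(=O)NCCCCCO)CN3c2ccccc2)cc1`, keeps the core and the benzamide of compound 1 and differs from it only at the chain end: 4-hydroxybutyl in place of amino on a saturated chain carbon bound to an amide-type nitrogen. Within the data shown here, that is a change of the same kind as the one between compound 2 and compound 3, and that step lay within the scatter. Compound 4 is therefore expected to stay close to compound 1, with a step of a 1.5-fold lower number from compound 1 to compound 4 (0.17 log units; within the scatter) expected and no clear direction. Compound 4 is estimated at 18000 nM, within a range of 7000 nM to 45000 nM.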

Compound 4, half-maximal inhibitory concentration: 9400 nM
The estimate for compound 4 lay 1.9-fold (0.28 log units) above the measured number, and the stated range covers the measured number.
By their numbers in this assay, from the lowest: compounds 4, 2 and 3 (each within the scatter of the next); then compound 1.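

In this assay the chain end proves able to move the number: a 2.8-fold lower number from compound 1 to compound 4 (0.45 log units; beyond the scatter) is a modest step beyond the scatter, with 4-hydroxybutyl in place of amino on a saturated chain carbon bound to an amide-type nitrogen. The earlier change at this chain end, a 1.3-fold higher number from compound 2 to compound 3 (0.10 log units; within the scatter), stayed within the scatter, so this position does not respond to every exchange, although a single step on the benzamide of compound 1 is all that supports this. No measurement shown explains the step.

It remains open whether the hydroxyl oxygen matters or the added chain alone, as a plain butyl chain, a 4-aminobutyl group or a carboxylic acid at this end is not among the compounds shown. As far as these compounds go, whether a longer chain would go further also remains open.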